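Linker Geometry Outweighs the Aryl Group Here

The source may hold more compounds than are shown below. What is called first, only, known or untested is meant among the compounds shown, and "the series" means these compounds.

Compound 3 `O=C1c2ccccc2C(=O)N1C/C=C/Cn1cc(C#CCCc2ccccc2)c(=O)[nH]c1=O` and compound 1 `CCCCc1ccc(C#Cc2cn(C/C=C/CN3C(=O)c4ccccc4C3=O)c(=O)[nH]c2=O)cc1` share one core and differ only in 4-butylphenyl in place of phenethyl on a triple-bonded carbon. In a functional assay on HepG2 cells (Homo sapiens) for antiproliferative activity, read by MTT assay, with a stated time of 3 days (on this read-out lower numbers stand for stronger inhibition and higher numbers for weaker inhibition), compound 3 gives 7300 nM, and compound 1 gives 9100 nM, which is a 1.2-fold higher number from compound 3 to compound 1 (0.10 log units; within the scatter). Compound 2 `O=C1c2ccccc2C(=O)N1C/C=C\Cn1cc(C#CCCc2ccccc2)c(=O)[nH]c1=O` has the same atoms as compound 3 and differs in the two compounds have the same atoms and bonds and differ only in configuration as drawn: 1 of 1 stereo elements differ; a double bond is drawn E in compound 3 and Z in compound 2. In this assay compound 2 reaches only a limit, > 100000 nM. Moving the other way gives an at least 13-fold lower number from compound 2 to compound 3 (1.13 log units; beyond the scatter), a large step that rests on the limit of > 100000 nM in this assay, at which 1 of the 3 values shown sits, together with the fact that compounds 2 and 3 differ only in the configuration as drawn. Compound 4 `CCCCc1ccc(C#Cc2cn(C/C=C\CN3C(=O)c4ccccc4C3=O)c(=O)[nH]c2=O)cc1` is not yet measured and differs from compound 2 by 4-butylphenyl in place of phenethyl on a triple-bonded carbon, the same change seen from compound 3 to compound 1. Because that earlier step was a 1.2-fold higher number from compound 3 to compound 1 (0.10 log units; within the scatter), compound 4 is expected to show a step that the limit leaves unreadable from compound 2 to compound 4. Compound 4 is therefore estimated at about 150000 nM, most likely again reported only as a limit.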

Compound 4, half-maximal inhibitory concentration: 40000 nM
Compound 4: the middle estimate sits 3.8-fold (0.57 log units) above what was measured, within the range that was stated.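

Swapping phenethyl for 4-butylphenyl with the double bond drawn Z gives an at least 2.5-fold lower number from compound 2 to compound 4 (0.39 log units; beyond the scatter) in this assay, so the change does not carry over unchanged from one double-bond form to the other: the same change on two cores in this assay, a 1.2-fold higher number (0.10 log units; within the scatter) from compound 3 to compound 1 and an at least 2.5-fold lower number (0.39 log units; beyond the scatter) from compound 2 to compound 4, at least 3.1-fold (0.49 log units) apart, beyond the scatter of two such steps. As far as these compounds go, compound 2 stands only as a limit, > 100000 nM, so the true size of its step stays unknown. The drawn configuration still separates the two 4-butylphenyl compounds, with a 4.4-fold higher number from compound 1 to compound 4 (0.64 log units; beyond the scatter), but these few pairs do not show why the swap behaves differently on the two forms.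

From the compounds shown here alone, it remains open whether other groups on the triple-bonded carbon, such as a longer chain or an amine, would follow the same pattern.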